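The source may hold more compounds than are shown below. What is called first, only, known or untested is meant among the compounds shown, and "the series" means these compounds.

Of the compounds shown here, three built on one shared core have been measured in a functional assay on HEK293 cells for agonist activity at Glucose-dependent insulinotropic receptor (Homo sapiens), read by fluorescence and cAMP accumulation, with a stated time of 30 min; a higher number here means a larger maximal response, a lower number a smaller maximal response. Compound 1 `COc1c(Nc2ccc(C#N)cc2Cl)ncnc1OC1C2COCC1CN(C(=O)OC1(C)CC1)C2` gives 88%, compound 2 `Cc1c(Nc2ccc(C#N)cc2Cl)ncnc1OC1C2COCC1CN(C(=O)OC1(C)CC1)C2` gives 74%, and compound 3 `Cc1c(Oc2ccc(C#N)cc2Cl)ncnc1OC1C2COCC1CN(C(=O)OC1(C)CC1)C2` gives 78%. Compound 2 has the lowest of these three numbers: its gap to compound 3 is within the scatter, whereas the step of a number 14 percentage points lower from compound 1 to compound 2 (beyond the scatter) was beyond it. Compound 4 `CC1(OC(=O)N2CC3COCC(C2)C3Oc2cc(Nc3ccc(C#N)cc3Cl)ncn2)CC1` differs from compound 2 by hydrogen in place of methyl on an aromatic carbon. For the measured compounds named here, the only measured step that alters this same group is a number 14 percentage points lower from compound 1 to compound 2 (beyond the scatter), a modest one, and no measured step removes the group outright. The expectation for this assay is therefore a step of a number 2 percentage points higher from compound 2 to compound 4 (within the scatter) small enough to stay within the scatter. Compound 4 is estimated at 76%, with a range from 60% to 92%.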

Compound 4, largest response reached (reported as percent of maximum), in percent of the reference or control that the assay uses: 88%
Compound 4: middle estimate off by 12 percentage points, on the low side, and the stated range covers the measured number.
By their numbers in this assay, from the lowest: compounds 2, 3, 1 and 4 (each within the scatter of the next, the first and the last beyond it).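

In this assay, hydrogen in place of methyl on this aromatic carbon gives a number 14 percentage points higher from compound 2 to compound 4 (beyond the scatter), while hydrogen in place of methoxy gives no change at the digits printed from compound 1 to compound 4 (within the scatter). The carbon therefore needs no group at all to reach the higher response, and among hydrogen, methoxy and methyl, only methyl goes with the lower number. Nothing measured here explains this.

On these data alone, whether an amine or an ethyl group on this carbon would keep the response remains open. So does whether hydrogen would act the same way alongside the 2-chloro-4-cyanophenoxy group of compound 3.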